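This account rests on a few compounds, and the source may have more. Where it says the series, first, only, none or still open, it means among the compounds named here.

Working notes on the series in an in vitro functional assay on HEK285-7 cells for antagonist activity at prostaglandin D2 receptor 2 (Homo sapiens), read by BRET and beta-arrestin recruitment; a lower number here means a stronger inhibitor, a higher number a weaker inhibitor.

Three compounds are measured. Compound 1 `O=C(O)Cc1sc(NCc2ccccc2)nc1-c1ccc(Cl)cc1` gives 2300 nM. Compound 2 `CS(=O)(=O)Nc1cccc(-c2nc(C(c3ccc(F)cc3)c3ccc(F)cc3)sc2CC(=O)O)c1` gives 370 nM. Compound 3 `O=C(O)Cc1sc(C(c2ccc(F)cc2)c2ccc(F)cc2)nc1-c1ccncc1` gives 40 nM, the lowest of the three numbers; the nearest is compound 2 and the furthest compound 1, both gaps beyond the scatter. For the measured compounds named here, the one single-point step measured so far, a 9.3-fold lower number from compound 2 to compound 3 (0.97 log units; beyond the scatter), concerns the aromatic group attached to the shared core and is modest in size.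

Compound 4 `CN(C)c1cc(-c2nc(C(c3ccc(F)cc3)c3ccc(F)cc3)sc2CC(=O)O)ccn1` keeps the whole of compound 3 and differs only by dimethylamino in place of hydrogen on an aromatic carbon. Going by the values given here, no measured step adds a substituent to that six-membered ring, so the step from compound 2 to compound 3 bears on it only as a sign that exchanges at this aromatic group shift the number modestly rather than drastically. Among the compounds with values here, with no closer precedent, the expected step of a 1.3-fold higher number from compound 3 to compound 4 (0.10 log units; within the scatter) is none beyond the scatter in either direction. Compound 4 is therefore estimated at 50 nM, with a range from 15 nM to 170 nM.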

Compound 4, half-maximal inhibitory concentration: > 100000 nM
Compound 4 ended at the assay's limit (the forecaster's own chance of this, stated with the estimate: 2%); middle value at least 2000-fold (3.30 log units) away from the limit.
By their numbers in this assay, from the lowest: compound 3; then compound 2; then compound 1. At a limit, above all of these: compound 4.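

In this assay compound 4 reads > 100000 nM, which is a limit of the assay and not a number: the limit of > 100000 nM in this assay, at which 1 of the 4 values shown sits. The earlier compounds shown here only exchanged the whole aromatic group, with a 9.3-fold lower number from compound 2 to compound 3 (0.97 log units; beyond the scatter), whereas dimethylamino in place of hydrogen next to the ring nitrogen gives an at least 2500-fold higher number from compound 3 to compound 4 (3.39 log units; beyond the scatter), so this single ring position is far more sensitive than that earlier exchange suggested. The 2-(dimethylamino)pyridin-4-yl group also falls well behind 3-(methanesulfonamido)phenyl, with an at least 270-fold higher number from compound 2 to compound 4 (2.43 log units; beyond the scatter).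

From the compounds shown here alone, whether a smaller group at this position, such as methyl, amino or fluorine, would keep the number close to that of compound 3 remains open. Also open, going by these compounds, is whether dimethylamino would be equally damaging on another carbon of the ring.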